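This account rests on a few compounds, and the source may have more. Where it says the series, first, only, none or still open, it means among the compounds named here.

Three compounds have so far been measured in an assay on membranes from HEK293 cells for displacement of a labelled ligand from adenosine receptor A2b (Homo sapiens), read by scintillation counting, with a stated time of 30 min, tested at 1 uM; on this read-out higher numbers stand for more inhibition at the one concentration tested (going by the name of the read-out) and lower numbers for less inhibition:

Compound 1, `COC(=O)C1=C(C)NC(=S)NC1c1cccs1`, gives 10%.
Compound 2, `CCCOC(=O)C1=C(C)NC(=S)NC1c1cccs1`, gives 3%.
Compound 3, `COC(=O)C1=C(C)NC(=S)NC1c1ccsc1`, gives 38%.

All three share the same core and differ only in the ester chain or in the thiophene group attached to the core. Compound 2 differs from compound 1 by ethyl in place of hydrogen on a saturated chain carbon bound to an oxygen next to a carbonyl group. That change gives a number 7 percentage points lower from compound 1 to compound 2 (within the scatter), so in this assay compound 1 and compound 2 lie within the usual scatter of each other and no order between them can be read. Compound 3 differs from compound 1 by thiophen-3-yl in place of thiophen-2-yl on a saturated ring carbon, and that change gives a number 28 percentage points higher from compound 1 to compound 3 (beyond the scatter). Compound 3 stands highest of the three, with its steps to compound 1 and to compound 2 both beyond the scatter.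

Compound 4, `CCCOC(=O)C1=C(C)NC(=S)NC1c1ccsc1`, has not yet been measured in this assay. It differs from compound 3 by ethyl in place of hydrogen on a saturated chain carbon bound to an oxygen next to a carbonyl group, the same change, at the same place, that turns compound 1 into compound 2. Among the compounds with values here, only that one measured pair shows what the change does, and there it stayed within the scatter. Because the same change earlier gave a number 7 percentage points lower from compound 1 to compound 2 (within the scatter), the expected step is a number 7 percentage points lower from compound 3 to compound 4 (within the scatter). With that step applied to the value of compound 3, compound 4 is estimated at 31% in this assay, most likely between 12% and 50%.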

Compound 4, a percentage reported as inhibition, at one concentration (the size of the read-out at that concentration, not a potency): 26%
Compound 4: the middle estimate sits 5 percentage points above what was measured, within the range that was stated.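

In this assay, replacing methoxycarbonyl with propoxycarbonyl on the thiophen-3-yl compounds gives a number 12 percentage points lower from compound 3 to compound 4 (beyond the scatter), and this step agrees with the one seen on the thiophen-2-yl compounds, even though only the newer step lies beyond the scatter: the same change on two cores in this assay, a number 7 percentage points lower (within the scatter) from compound 1 to compound 2 and a number 12 percentage points lower (beyond the scatter) from compound 3 to compound 4, 5 percentage points apart, within the scatter of two such steps

The thiophene change also carries over when the ester is propoxycarbonyl, where thiophen-3-yl in place of thiophen-2-yl gives a number 23 percentage points higher from compound 2 to compound 4 (beyond the scatter), again much like the step seen with the methoxycarbonyl compounds: the same change on two cores in this assay, a number 28 percentage points higher (beyond the scatter) from compound 1 to compound 3 and a number 23 percentage points higher (beyond the scatter) from compound 2 to compound 4, 5 percentage points apart, within the scatter of two such steps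

Within the data shown here, this agreement rests on only one pair of steps for each change, all read at a single concentration, so it shows that the two changes behaved alike within these four compounds, but it does not show that they would carry over to other cores or that they would shift potency in the same way.

The compounds shown leave open what an ethoxycarbonyl group or a longer chain such as butoxycarbonyl would do in the ester position, and whether a carboxylic acid or an amide could take the place of the ester. They also leave open how a phenyl or furan-3-yl group would compare with thiophen-3-yl on the same saturated ring carbon.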